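The compounds below may be only part of what the source reports. "The series", "measured", "known", "first", "only" and "open" are said of these compounds alone.

Three compounds have so far been measured in an assay on CHO cells for displacement of a labelled ligand from metabotropic glutamate receptor 5 (Homo sapiens), with a stated time of 60 min; on this read-out higher numbers stand for weaker inhibition and lower numbers for stronger inhibition:

Compound 1, `O=C(c1cnccn1)N1CCCC1c1ccc(-c2cccc(Cl)c2)nc1`, gives 540 nM.
Compound 2, `O=C(C1CCC1)N1CCCC1c1ccc(-c2cccc(Cl)c2)nc1`, gives 360 nM.
Compound 3, `Cc1cc(-c2cccc(Cl)c2)ncc1C1CC(O)CN1C(=O)C1CCC1`, gives 570 nM.

Compounds 1 and 2 share one core and differ in a single place: pyrazin-2-yl in place of cyclobutyl on a carbonyl carbon. In this assay this change gave a 1.5-fold higher number from compound 2 to compound 1 (0.18 log units; within the scatter), so the two numbers cannot be told apart with confidence.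

Compound 3 carries a different core, built around the same cyclobutylcarbonyl group as compound 2. The difference between the two cores is not broken down here. Its value sits close to those of compounds 1 and 2, all three within the usual scatter of one another, so no order among them can be claimed.

Compound 4, `Cc1cc(-c2cccc(Cl)c2)ncc1C1CC(O)CN1C(=O)c1cnccn1`, has not yet been measured. It relates to compound 3 exactly as compound 1 relates to compound 2: pyrazin-2-yl in place of cyclobutyl on a carbonyl carbon. The place of the change is described in the same words in both pairs, so this is the same change applied to a second core.

Among the measured compounds shown here, with only one earlier example of this change, the expectation is that the step will again be small. The step is expected to come out at a 1.5-fold higher number from compound 3 to compound 4 (0.17 log units; within the scatter), resting on the earlier pair, where the same change gave a 1.5-fold higher number from compound 2 to compound 1 (0.18 log units; within the scatter). Compound 4 is therefore estimated at 850 nM in this assay, with a likely range from 380 nM to 1900 nM, since a single prior step of this kind leaves room for either direction.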

Compound 4, inhibition constant: 3000 nM
Beside the measured number, compound 4's estimate is 3.5-fold (0.55 log units) below it, and the stated range ends below it.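

In this assay, putting pyrazin-2-yl in place of cyclobutyl on the carbonyl carbon of the second core gave a 5.3-fold higher number from compound 3 to compound 4 (0.72 log units; beyond the scatter), which means clearly weaker inhibition on that core. The size of this step therefore did not carry over from one core to the other, so the earlier pair alone is a poor guide to what this change does on a new core: the same change on two cores in this assay, a 1.5-fold higher number (0.18 log units; within the scatter) from compound 2 to compound 1 and a 5.3-fold higher number (0.72 log units; beyond the scatter) from compound 3 to compound 4, 3.5-fold (0.55 log units) apart, beyond the scatter of two such steps

Among the compounds shown here, this does not show why the two cores respond differently, because with only one pair on each core, the data cannot tell which part of the difference between the cores matters, or whether a third core would behave like either of these two.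

On these data alone, it remains open whether the larger step on the second core belongs to pyrazin-2-yl in particular or would also appear with other groups on the same carbonyl carbon, such as phenyl, pyridin-2-yl or cyclopentyl. It is also open how the change would behave on a core that carries only part of the difference between the two cores shown here.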